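The source may hold more compounds than are shown below. What is called first, only, known or untested is meant among the compounds shown, and "the series" means these compounds.

Measured so far in a functional assay on A2780 cells (Homo sapiens) for antiproliferative activity, read by resazurin assay, with a stated time of 72 h; a higher number here means a weaker inhibitor, a lower number a stronger inhibitor:

compound 1 `CCCN(C)C(=O)c1cc2c(Cc3ccccc3)n[nH]c2cc1O`: > 10000 nM (a limit of the assay, not a number)
compound 2 `CN(Cc1ccccc1Cl)C(=O)c1cc2c(Cc3ccccc3)n[nH]c2cc1O`: 1100 nM
compound 3 `CN(Cc1cccc(C(F)(F)F)c1)C(=O)c1cc2c(Cc3ccccc3)n[nH]c2cc1O`: "not determined" (no result reported)

Compound 3 offers no number to start from. Its entry in this assay reads "not determined" (no result reported) and so it stands nowhere on the scale, and the step away from it cannot be sized.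

The next compound is compound 4 `Cc1ccc(CN(C)C(=O)c2cc3c(Cc4ccccc4)n[nH]c3cc2O)cc1`, and the change is 4-methylphenyl in place of 3-(trifluoromethyl)phenyl on a saturated chain carbon bound to an amide-type nitrogen.

Among the compounds with values here, only one measured step touches this same place. It is an at least 9.0-fold lower number from compound 1 to compound 2 (0.95 log units; beyond the scatter), with 2-chlorophenyl in place of ethyl, and it lies beyond the scatter. On these data alone, its true size stays open, since it starts from a limit.

Compound 4 keeps an aromatic ring of carbon at this place, as does compound 2 at 1100 nM in this assay, so a value in that neighbourhood is the natural expectation. No direction or size can be given for the step from compound 3, and a single measured compound with such a ring is thin support.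

For compound 4 the expected value is 1500 nM, with an estimated range from 400 nM to 6000 nM in this assay.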

Compound 4, half-maximal inhibitory concentration: 6900 nM
Compound 4: the middle estimate sits 4.6-fold (0.66 log units) below what was measured, and the stated range ends below it.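

In this assay this position, on a saturated chain carbon bound to an amide-type nitrogen, responds to which aromatic ring it carries and not merely to whether it carries one: 4-methylphenyl in place of 2-chlorophenyl gives a 6.3-fold higher number from compound 2 to compound 4 (0.80 log units; beyond the scatter) at this place. Within the data shown here, until now, compound 2 was the only measured compound here with a number, so it could not be told whether any such ring would do as well; compound 4 shows that 4-methylphenyl does not match 2-chlorophenyl in this assay. Compound 1 holds a limit and not a number: the limit of > 10000 nM in this assay, at which 1 of the 4 values shown sits.
For 4-methylphenyl in place of ethyl the data give an at least 1.4-fold lower number from compound 1 to compound 4 (0.16 log units; that floor lies within the scatter) and this cannot be read as a size, so no gain of 4-methylphenyl over ethyl can be claimed.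

The two rings differ both in the group they carry and in where it sits, so this single step cannot say which of the two differences matters, and compound 3 still gives no value to set beside them. An unsubstituted phenyl ring would give a plain reference point for both rings, and a chain ending in an amine would test whether an aromatic ring is needed here at all.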